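The compounds below may be only part of what the source reports. "The series", "measured", "known", "first", "only" and "open" are said of these compounds alone.

Of the compounds shown here, three built on one shared core have been measured in an assay on isolated protein for inhibition of Dihydrofolate reductase (Mus musculus); a higher number here means a more potent compound, by a factor of ten per unit of this negative logarithm, a lower number a less potent compound. Compound 1 `CC1(C)N=C(N)N=C(N)N1c1ccc(OCCCNC(=O)Nc2ccc(S(=O)(=O)F)cc2)c(Cl)c1` gives 7.68 in this assay. Compound 3 `CC1(C)N=C(N)N=C(N)N1c1ccc(OCCCNC(=O)Nc2cccc(S(=O)(=O)F)c2)c(Cl)c1` differs from compound 1 in a single place, (3-(fluorosulfonyl)phenyl in place of 4-(fluorosulfonyl)phenyl on an amide-type nitrogen), and in this assay compound 3 gives 7.28; the change brought a number 0.40 log units lower from compound 1 to compound 3 (beyond the scatter). Compound 2 `CC1(C)N=C(N)N=C(N)N1c1ccc(SCC(=O)Nc2ccc(S(=O)(=O)F)cc2)c(Cl)c1` is built differently between the shared core and the outer ring, and the difference between the two cores is not broken down here. In this assay compound 2 gives 7.42, which lies within the scatter of both compound 3 and compound 1.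

Compound 4 `CC1(C)N=C(N)N=C(N)N1c1ccc(SCC(=O)Nc2cccc(S(=O)(=O)F)c2)c(Cl)c1` has not yet been measured. It stands to compound 2 as compound 3 stands to compound 1: the same change, (3-(fluorosulfonyl)phenyl in place of 4-(fluorosulfonyl)phenyl on an amide-type nitrogen), at a place described in the same words. Because the earlier step of a number 0.40 log units lower from compound 1 to compound 3 (beyond the scatter) was modest but beyond the scatter, compound 4 is expected to sit a little lower than compound 2, with an estimated step of a number 0.37 log units lower from compound 2 to compound 4 (beyond the scatter). Compound 4 is therefore estimated at 7.05, expected to fall between 6.65 and 7.45.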

Compound 4, logarithm of the reciprocal of the active concentration, log(1/C): 7.66
Beside the measured number, compound 4's estimate is 0.61 log units below it, and the stated range ends below it.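

The same change, 3-(fluorosulfonyl)phenyl in place of 4-(fluorosulfonyl)phenyl on an amide-type nitrogen, gives a number 0.24 log units higher from compound 2 to compound 4 (within the scatter) in this assay. Set beside the earlier step, this shows that the change did not carry over from one core to the other: the same change on two cores in this assay, a number 0.40 log units lower (beyond the scatter) from compound 1 to compound 3 and a number 0.24 log units higher (within the scatter) from compound 2 to compound 4, 0.64 log units apart, beyond the scatter of two such steps In this series, then, a step read on the core of compound 1 gives no safe estimate for the core of compound 2, but with only one pair on each core, these numbers do not show which feature of the two cores lies behind the gap, nor what the change would do on a third core.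

The compounds shown leave open how the 3- and 4-substituted rings would compare with a carboxylic acid or a sulfonamide in place of the fluorosulfonyl group. For the compounds shown here, they also leave open whether a longer chain between the shared core and the outer ring would give the step seen with compound 1 and compound 3, the one seen with compound 2 and compound 4, or neither.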